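Anilino variation on the shared core: toward compound 4

The source may hold more compounds than are shown below. What is called first, only, known or untested is meant among the compounds shown, and "the series" means these compounds.

The series keeps the core of compound 3 `CCS(=O)(=O)Nc1cc(-c2ccc3ncnc(Nc4ccc(F)cc4F)c3c2)cnc1OC` and varies the aromatic group on the nitrogen. In a functional assay on A549 cells (Homo sapiens) for cytotoxicity, read by sulforhodamine B assay, with a stated time of 72 h (a higher number here means a weaker inhibitor, a lower number a stronger inhibitor), compound 1 `CCS(=O)(=O)Nc1cc(-c2ccc3ncnc(Nc4cccc(F)c4)c3c2)cnc1OC` gives 9940 nM, compound 2 `CCS(=O)(=O)Nc1cc(-c2ccc3ncnc(Nc4ccc(F)cc4)c3c2)cnc1OC` gives 7620 nM, and compound 3 gives 4710 nM, the lowest number of the three, separated from compound 1 but not from compound 2 beyond the scatter. The aryl exchanges moved the readout by a 1.3-fold lower number from compound 1 to compound 2 (0.12 log units; within the scatter), a 1.6-fold lower number from compound 2 to compound 3 (0.21 log units; within the scatter) and a 2.1-fold lower number from compound 1 to compound 3 (0.32 log units; beyond the scatter). Compound 4 `CCS(=O)(=O)Nc1cc(-c2ccc3ncnc(Nc4ccc(OC)c(Cl)c4)c3c2)cnc1OC` carries 3-chloro-4-methoxyphenyl in place of 2,4-difluorophenyl on a nitrogen on an aromatic ring. Among the compounds with values here, no measured pair covers this exact exchange; the three aryl swaps are the only guide, and all were small. The step from compound 3 to compound 4 is therefore expected to be a 1.0-fold lower number from compound 3 to compound 4 (0.02 log units; within the scatter), within or barely beyond the scatter. Compound 4 is estimated at 4500 nM, in the range 1500 nM to 13000 nM.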

Compound 4, half-maximal inhibitory concentration: 5240 nM
Compound 4: middle estimate off by 1.2-fold (0.07 log units), on the low side; the range from low to high includes it.
By their numbers in this assay, from the lowest: compounds 3, 4, 2 and 1 (each within the scatter of the next, the first and the last beyond it).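

In this assay the larger 3-chloro-4-methoxyphenyl group, the only one here carrying a hydrogen-bond acceptor, does not separate from any of the fluorophenyl groups: a 1.1-fold higher number from compound 3 to compound 4 (0.05 log units; within the scatter) and a 1.5-fold lower number from compound 2 to compound 4 (0.16 log units; within the scatter) and a 1.9-fold lower number from compound 1 to compound 4 (0.28 log units; within the scatter). This position on the nitrogen therefore accepts chloro and methoxy groups as well as fluoro without a readable shift, so the aryl exchanges shown remain a flat stretch of the series. No measurement on hand explains this flatness.

As far as these compounds go, whether an aminomethyl or carboxylic acid group on this aryl ring would move the number remains open. So does the effect of replacing the aryl ring with a saturated amine such as piperidine.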